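The source may hold more compounds than are shown below. What is called first, only, known or untested is meant among the compounds shown, and "the series" means these compounds.

Compound 1 `COc1ccc(/C=C2\CCc3cc(OC)c(OC)cc3C2=O)cc1` and compound 2 `COc1ccc(/C=C2\CCc3cc(OC)c(OC)cc3C2=O)c(OC)c1` share a core, and compound 3 `COc1cc(/C=C2\CCc3cc(OC)c(OC)cc3C2=O)cc(OC)c1` is built on a related core; how the core of compound 3 differs from that of compound 1 is not broken down here. In a functional assay on Jurkat cells (Homo sapiens) for antiproliferative activity, read by MTT assay (a lower number here means a stronger inhibitor, a higher number a weaker inhibitor), compound 1 gives only a limit of the assay, > 50000 nM. In this assay compound 2 likewise gives only a limit, > 50000 nM. The step that the two limits leave unreadable from compound 1 to compound 2 therefore cannot be read, because both values sit at the limit of > 50000 nM in this assay, at which 2 of the 3 values shown sit. Among the compounds with values here, compound 3 is the one compound of the three with a number: in this assay compound 3 gives 5000 nM.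

Compound 4 `COc1cc2c(cc1OC)C(=O)/C(=C/c1cc(OC)c(OC)c(OC)c1)CC2` has not yet been measured. The change from compound 3 to compound 4 is methoxy in place of hydrogen on an aromatic carbon. The same kind of change separates compound 1 from compound 2, where it is methoxy in place of hydrogen on an aromatic carbon; the two places are not the same, since in compound 4 the entering group sits ortho to two methoxy groups and para to a large group, whereas in compound 2 it sits ortho to a large group and meta to a methoxy group.

Because the measured example of this change, a step that the two limits leave unreadable from compound 1 to compound 2, is unreadable, nothing of its size carries over. Within the data shown here, compound 3 is, however, the only compound with a measurable value in this assay, and adding a third methoxy group to it is expected to give a modest gain, a step of about a 5.0-fold lower number from compound 3 to compound 4 (0.70 log units; beyond the scatter). Compound 4 is therefore estimated at 1000 nM in this assay, with a plausible range from 150 nM to 6000 nM.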

Compound 4, half-maximal inhibitory concentration: > 50000 nM
Compound 4: only a limit was reported; the forecaster's own chance of this, stated with the estimate: 5%; middle value at least 50-fold (1.69 log units) away from the limit.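

In this assay, methoxy in place of hydrogen on an aromatic carbon, ortho to two methoxy groups and para to a large group, gives an at least 10-fold higher number from compound 3 to compound 4 (1.00 log units; beyond the scatter), so at this place on the core of compound 3 the change weakens the compound rather than strengthening it. Compound 4 gives only a limit of the assay, > 50000 nM. This one readable step shows what the change does at a single place on a single core, but it does not show how the change carries from one core to another: the step from compound 1 to compound 2 cannot be read, the two examples differ in place as well as in core, and most of the set gives no number to compare: the limit of > 50000 nM in this assay, at which 3 of the 4 values shown sit.

The compounds shown leave open whether a hydroxyl group, a fluorine atom or an amine at the place taken by the entering methoxy group in compound 4 would keep a number in this assay. They also leave open whether a longer chain such as ethoxy at that place would behave as methoxy does, and whether any such group would give a readable step on the core of compound 1.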